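Benzyloxycarbonyl for Trifluoromethyl on the Fluorophenyl Core

The source may hold more compounds than are shown below. What is called first, only, known or untested is meant among the compounds shown, and "the series" means these compounds.

Measured in a functional assay on HeLa cells (Homo sapiens) for antiproliferative activity, read by MTT assay, with a stated time of 48 h; on this read-out lower numbers stand for stronger inhibition and higher numbers for weaker inhibition:
compound 1, `FC(F)(F)c1ccc2[nH]c(-c3cn(-c4ccccc4)nc3-c3ccccc3)nc2c1`, gives 1920 nM
compound 2, `O=C(OCc1ccccc1)c1ccc2[nH]c(-c3cn(-c4ccccc4)nc3-c3ccccc3)nc2c1`, gives 21300 nM
compound 3, `Fc1ccc(-c2nn(-c3ccccc3)cc2-c2nc3cc(C(F)(F)F)ccc3[nH]2)cc1`, gives 3520 nM

Compound 4, `O=C(OCc1ccccc1)c1ccc2[nH]c(-c3cn(-c4ccccc4)nc3-c3ccc(F)cc3)nc2c1`, has not been measured in this assay. It differs from compound 3 by benzyloxycarbonyl in place of trifluoromethyl on an aromatic carbon. The same change has been made once before, from compound 1 to compound 2, where it gave an 11-fold higher number from compound 1 to compound 2 (1.05 log units; beyond the scatter). The two cores differ by fluoro in place of hydrogen on an aromatic carbon; the place of the change is described in the same words in both pairs, so the two changes are of the same kind. Compound 3 stands near compound 1, the step being a 1.8-fold higher number from compound 1 to compound 3 (0.26 log units; within the scatter). For compound 4 a step of a 10-fold higher number from compound 3 to compound 4 (1.01 log units; beyond the scatter) is expected, resting on the earlier step of an 11-fold higher number from compound 1 to compound 2 (1.05 log units; beyond the scatter) applied to compound 3 at 3520 nM. Compound 4 is therefore estimated at 36000 nM, within 12000 nM to 100000 nM.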

Compound 4, half-maximal inhibitory concentration: 23600 nM
Estimate against measurement, compound 4: 1.5-fold (0.18 log units) above, and the stated range covers the measured number.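

In this assay the exchange of trifluoromethyl for benzyloxycarbonyl on the fluoro-bearing core gives a 6.7-fold higher number from compound 3 to compound 4 (0.83 log units; beyond the scatter), and this agrees with the step on the core without fluoro: the same change on two cores in this assay, an 11-fold higher number (1.05 log units; beyond the scatter) from compound 1 to compound 2 and a 6.7-fold higher number (0.83 log units; beyond the scatter) from compound 3 to compound 4, 1.7-fold (0.22 log units) apart, within the scatter of two such steps. Fluoro in place of hydrogen gives a 1.1-fold higher number from compound 2 to compound 4 (0.04 log units; within the scatter) on the benzyloxycarbonyl core, which also agrees with its counterpart: the same change on two cores in this assay, a 1.8-fold higher number (0.26 log units; within the scatter) from compound 1 to compound 3 and a 1.1-fold higher number (0.04 log units; within the scatter) from compound 2 to compound 4, 1.7-fold (0.22 log units) apart, within the scatter of two such steps. The change thus carries across this one difference between cores, but two cores separated by a single fluoro do not show that it would hold on a core altered elsewhere, and they do not show why the number rises.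

The compounds shown leave open how a carboxylic acid, a methyl ester or an amine would behave in place of these two groups. Also open, on these data alone, is whether chloro or methoxy in place of the fluoro would leave the step the same.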